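The source may hold more compounds than are shown below. What is called first, only, known or untested is meant among the compounds shown, and "the series" means these compounds.

Measured compounds:
compound 1, `O=C(/C(=C\c1ccc(Br)cc1)Sc1ccc(Br)cc1)c1ccc(Cl)cc1`: in a functional assay on DU-145 cells (Homo sapiens) for inhibition, read by trypan blue exclusion, with a stated time of 96 h (a higher number here means a weaker inhibitor of growth, a lower number a stronger inhibitor of growth), compound 1 gives 1000 nM
compound 2, `COc1ccccc1/C=C(/SCc1ccc(Cl)c(Cl)c1)C(=O)c1ccc(Cl)cc1`: in this assay compound 2 gives 10000 nM
compound 3, `O=C(/C(=C\c1ccc(F)cc1F)Sc1ccc(Br)cc1)c1ccc(Cl)cc1`: in this assay compound 3 gives 1000 nM

Compound 3 stands level with compound 1 on these numbers, and the two together hold the lowest values of the three; compound 2 sits above both. Among the compounds with values here, the one step that changes a single place, no change at the digits printed from compound 1 to compound 3 (within the scatter), swaps the aryl group on the double-bonded chain carbon and leaves the number where it was.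

Compound 4, `COc1ccccc1/C=C(/Sc1ccc(Br)cc1)C(=O)c1ccc(Cl)cc1`, is not yet measured. 2-methoxyphenyl in place of 2,4-difluorophenyl on a double-bonded chain carbon bound to a double-bonded chain carbon This is the same place that moved between compound 1 and compound 3 without effect, so on that step alone no change beyond the scatter would be expected. Within the data shown here, compound 2, however, also carries the 2-methoxyphenyl and gives the highest number of the set; it differs from compound 4 elsewhere in the structure and no step between them is known, so how much of its value belongs to the 2-methoxyphenyl cannot be told. The estimate for compound 4 is therefore set between those two readings, with a wide range: 3000 nM (1000 nM to 10000 nM). This means an expected step of a 3.0-fold higher number from compound 3 to compound 4 (0.48 log units; beyond the scatter).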

Compound 4, concentration for 50% growth inhibition: 10000 nM
Compound 4: the middle estimate sits 3.3-fold (0.52 log units) below what was measured; the measured number falls inside the stated range.
By their numbers in this assay, from the lowest: compounds 1 and 3 (each within the scatter of the next); then compounds 2 and 4 (each within the scatter of the next).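

In this assay, the aryl group on a double-bonded chain carbon bound to a double-bonded chain carbon is now seen to matter: 2-methoxyphenyl in place of 2,4-difluorophenyl gives a 10-fold higher number from compound 3 to compound 4 (1.00 log units; beyond the scatter) (and in place of 4-bromophenyl gives a 10-fold higher number from compound 1 to compound 4 (1.00 log units; beyond the scatter)), whereas the earlier swap between those two aryl groups gave no change at the digits printed from compound 1 to compound 3 (within the scatter) (so the position does not tolerate every aryl group alike). With 2-methoxyphenyl in that place, the group on the sulfur does not separate the two compounds: 4-bromophenyl in place of 3,4-dichlorobenzyl gives no change at the digits printed from compound 2 to compound 4 (within the scatter) (a reading limited to this one aryl group). Within the data shown here, nothing measured so far offers an explanation for the step at this position.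

On these data alone, whether an aminophenyl or hydroxyphenyl group in the same place would read like compound 3 or like compound 4 remains open. Also open, as far as these compounds go, is whether 3,4-dichlorobenzyl on the sulfur would leave the number unchanged with 2,4-difluorophenyl on the chain carbon.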